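This account rests on a few compounds, and the source may have more. Where it says the series, first, only, none or still open, it means among the compounds named here.

Three compounds built on the shared core of compound 1 `CCCCCCCCCCCCCCCC(=O)NCc1ccc(O)c(OC)c1` have been tested in an assay on HEK293 cells for antagonist activity at transient receptor potential cation channel subfamily V member 2 (Rattus norvegicus), read by fluorescence and calcium flux, with a stated time of 5 min; on this read-out lower numbers stand for stronger inhibition and higher numbers for weaker inhibition. Compound 1 carries a long saturated chain on its amide. In this assay compound 1 gives only a limit, > 10000 nM, and not a number. Compound 3 `CCCCCCC(=O)CC(O)CCCCCCCCC(=O)NCc1ccc(O)c(OC)c1`, with a ketone and a hydroxyl in its chain, likewise gives only a limit in this assay, > 10000 nM. Among the measured compounds shown here, compound 2 `CCCCCCCC/C=C\CCCCCCCC[Se]C[C@H](N)C(=O)NCc1ccc(O)c(OC)c1`, in which a selenium-containing amino acid links an unsaturated chain to the core, is the one compound of the three that gives a number in this assay, namely 980 nM. For the measured compounds named here, compound 1 therefore stands at the limit of > 10000 nM in this assay, at which 2 of the 3 values shown sit, and no step between measured compounds can be drawn from it.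

Compound 4 `CCCCCCCCCCCCCCCCCC(=O)NCc1ccc(O)c(OC)c1` differs from compound 1 in one place: ethyl in place of hydrogen on a saturated chain carbon, ten or more bonds along the chain from a carbonyl carbon. Going by the values given here, no pair of measured compounds shows the effect of such a lengthening of a saturated chain, so there is nothing to set the size of the step from. The step expected in this assay is a step that the limit leaves unreadable from compound 1 to compound 4, which amounts to no change beyond the usual scatter. The estimate for compound 4 is accordingly 15000 nM, with a range from 5000 nM to 50000 nM, and most likely only another limit would be read.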

Compound 4, half-maximal inhibitory concentration: > 10000 nM
Compound 4: no number, only a limit; the forecaster's own chance of this, stated with the estimate: 75%; the middle value lies beyond the limit too.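

Compound 1 and compound 4 both give only a limit and not a number, so no step can be read between them: the limit of > 10000 nM in this assay, at which 3 of the 4 values shown sit.

Still open, going by these compounds, is whether lengthening the saturated chain changes inhibition at all, and which of the several differences in compound 2 goes with its measured number.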